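Methoxy on the cinnamamide phenyl: a step expected to stay flat

The source may hold more compounds than are shown below. What is called first, only, known or untested is meant among the compounds shown, and "the series" means these compounds.

Measured compounds:
Compound 1, `COc1ccc(/C=C/C(=O)Nc2cc3c(Nc4ccc(Cl)c(Cl)c4)ncnc3s2)cc1`, gives 30600 nM.
Compound 2, `O=C(/C=C/c1ccccc1)Nc1cc2c(Nc3ccc(Cl)c(Cl)c3)ncnc2s1`, gives 30100 nM.
Compound 3, `O=C(/C=C/c1ccccc1)Nc1cc2ncnc(Nc3ccc(F)c(Cl)c3)c2s1`, gives 10600 nM.

All three were tested in a functional assay on HepG2 cells (Homo sapiens) for antiproliferative activity, read by MTT assay, with a stated time of 48 h; a lower number here means a stronger inhibitor, a higher number a weaker inhibitor. Compound 1 and compound 2 share a core and differ only by methoxy in place of hydrogen on an aromatic carbon; that change gave a 1.0-fold higher number from compound 2 to compound 1 (0.01 log units; within the scatter). Compound 3 carries a different core; the difference between the two cores is not broken down here. Among the three, compound 3 shows the lowest number, with compound 2 and compound 1 standing at higher numbers beyond the scatter.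

Compound 4, `COc1ccc(/C=C/C(=O)Nc2cc3ncnc(Nc4ccc(F)c(Cl)c4)c3s2)cc1`, has not yet been measured. It differs from compound 3 by methoxy in place of hydrogen on an aromatic carbon, the same change that separates compound 2 from compound 1, at the same place. Because the earlier step was a 1.0-fold higher number from compound 2 to compound 1 (0.01 log units; within the scatter), the step from compound 3 to compound 4 is expected to be a 1.0-fold higher number from compound 3 to compound 4 (0.02 log units; within the scatter), that is, essentially flat. Compound 4 is therefore estimated at 11000 nM, between 5000 nM and 25000 nM.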

Compound 4, half-maximal inhibitory concentration: 13900 nM
Compound 4: the middle estimate sits 1.3-fold (0.10 log units) below what was measured, and the stated range covers the measured number.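

In this assay, the change from phenyl to 4-methoxyphenyl on the core of compound 3 gave a 1.3-fold higher number from compound 3 to compound 4 (0.12 log units; within the scatter), so the step stayed flat on this core as well. Set beside the step on the core of compound 2, the two results agree: the same change on two cores in this assay, a 1.0-fold higher number (0.01 log units; within the scatter) from compound 2 to compound 1 and a 1.3-fold higher number (0.12 log units; within the scatter) from compound 3 to compound 4, 1.3-fold (0.11 log units) apart, within the scatter of two such steps. This shows that, on these two cores, methoxy in place of hydrogen carried over with no difference that can be told from the scatter; it does not show that the same would hold on any other core, and it does not explain why the number stays flat.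

The compounds shown leave open whether another group on the same aromatic carbon, such as a hydroxyl, an amine or a carboxylic acid, would also leave the number flat, and whether such a group would carry over between the two cores as methoxy does. They also leave open how a longer chain in place of methoxy would behave, and whether the flat step would appear in any read-out other than this assay.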